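Ring Substitution and Potency in a Reductase Inhibitor Series

This account rests on a few compounds, and the source may have more. Where it says the series, first, only, none or still open, it means among the compounds named here.

Measured compounds:
compound 1, `Cc1ccccc1-c1cc(Cl)cc(Cl)c1/C=C/[C@@H]1C[C@@H](O)CC(=O)O1`, 370 nM
compound 2, `Cc1cc(C)cc(-c2cc(Cl)cc(Cl)c2/C=C/[C@@H]2C[C@@H](O)CC(=O)O2)c1`, 13 nM
compound 3, `Cc1cc(F)ccc1-c1cc(Cl)cc(Cl)c1/C=C/[C@@H]1C[C@@H](O)CC(=O)O1`, 36 nM

All three share one core and differ only in the aryl group carried on an aromatic carbon. In an assay for inhibition of 3-hydroxy-3-methylglutaryl-coenzyme A reductase (Rattus norvegicus) (a higher number here means a weaker inhibitor, a lower number a stronger inhibitor), compound 1 gives 370 nM, compound 2 gives 13 nM and compound 3 gives 36 nM. Compound 3 stands in the middle of these numbers: a 2.8-fold higher number from compound 2 to compound 3 (0.44 log units; beyond the scatter), while a 10-fold lower number from compound 1 to compound 3 (1.01 log units; beyond the scatter).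

Compound 4, `O=C1C[C@H](O)C[C@@H](/C=C/c2c(Cl)cc(Cl)cc2-c2cccc(F)c2)O1`, has not yet been measured. The change is 3-fluorophenyl in place of 4-fluoro-2-methylphenyl on an aromatic carbon, placed on an aromatic carbon of a six-membered aromatic ring of carbon only, ortho to a large group and meta to two chloro groups. Among the compounds with values here, no measured step removes the methyl alone or moves the fluoro alone. Within the data shown here, two steps bear on it indirectly: a 10-fold lower number from compound 1 to compound 3 (1.01 log units; beyond the scatter) shows that a fluoro on this ring strongly lowers the number, and a 28-fold lower number from compound 1 to compound 2 (1.45 log units; beyond the scatter) shows that substitution away from the 2-position of the ring is well tolerated, indeed strongly favoured. Keeping a fluoro while dropping the methyl is therefore expected to leave the number close to that of compound 3, with at most a modest step in either direction. The expected step is a 1.4-fold lower number from compound 3 to compound 4 (0.16 log units; within the scatter). Compound 4 is expected to give 25 nM in this assay, within the range 8 nM to 80 nM.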

Compound 4, half-maximal inhibitory concentration: 70 nM
The estimate for compound 4 lay 2.8-fold (0.45 log units) below the measured number; the range from low to high includes it.
By their numbers in this assay, from the lowest: compound 2; then compounds 3 and 4 (each within the scatter of the next); then compound 1.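

Read in this assay, the swap to 3-fluorophenyl gives a 1.9-fold higher number from compound 3 to compound 4 (0.29 log units; within the scatter), so compound 4 cannot be told apart from compound 3, and an aryl group with no methyl at all can match one that carries a methyl. Compound 4 does stand apart from the other two, with one step (a 5.3-fold lower number from compound 1 to compound 4 (0.72 log units; beyond the scatter)) and another (a 5.4-fold higher number from compound 2 to compound 4 (0.73 log units; beyond the scatter)), both beyond the scatter. Both fluoro compounds therefore have lower numbers than the 2-methylphenyl compound 1, yet fluoro is not required for a low number, since compound 2 has the lowest number of the four and carries none. Nothing on hand offers a measured reason for any of these differences.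

Compound 3 and compound 4 differ in the methyl and in the place of the fluoro at once, so the contribution of each cannot be separated. Also open is how this position would respond to an aryl group bearing an amine, a hydroxyl or a carboxylic acid, since the compounds shown carry only methyl and fluoro there.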